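The source may hold more compounds than are shown below. What is called first, only, known or untested is meant among the compounds shown, and "the series" means these compounds.

Measured compounds:
- compound 1, `C/C=C/C(=O)N(Cc1cccc(O)c1)c1cc(OC)c(OC)c(OC)c1` — 14100 nM
- compound 2, `CCC/C=C/C(=O)N(Cc1ccc(OC)c(O)c1)c1cc(OC)c(OC)c(OC)c1` — 70 nM

The two measured compounds were tested in a functional assay on MGC-803 cells (Homo sapiens) for inhibition, read by MTT assay, with a stated time of 48 h; a higher number here means a weaker inhibitor, a lower number a stronger inhibitor. Compound 1 gives 14100 nM, while compound 2 gives 70 nM, the lower of the two numbers and therefore the stronger inhibitor in this pair; the two compounds differ at more than one place, so their gap cannot be traced to a single change.

Compound 3, `CCC(=O)N(Cc1ccc(OC)c(O)c1)c1cc(OC)c(OC)c(OC)c1`, has not yet been measured. It differs from compound 2 in one place: ethyl in place of pent-1-en-1-yl on a carbonyl carbon. The pent-1-en-1-yl group leaves, taking its double bond outside aromatic rings with it, and the shorter ethyl enters on the same carbonyl carbon.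

Within the data shown here, no measured pair shows this change on its own, so the direction of the step is uncertain. Compound 2 carries the longest, unsaturated acyl chain in the set and gives 70 nM; the step from it to compound 3 is expected to run upward, towards a weaker inhibitor, by a 21-fold higher number from compound 2 to compound 3 (1.33 log units; beyond the scatter). Compound 3 is thus estimated at 1500 nM, within a range from 150 nM to 15000 nM.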

Compound 3, half-maximal inhibitory concentration: 50 nM
Estimate against measurement, compound 3: 30-fold (1.48 log units) above; the measured number lies below the stated range.
By their numbers in this assay, from the lowest: compounds 3 and 2 (each within the scatter of the next); then compound 1.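

In this assay, the first pair differing in one place gives a 1.4-fold lower number from compound 2 to compound 3 (0.15 log units; within the scatter), so the two compounds cannot be told apart in this assay. On a carbonyl carbon whose other neighbour is an amide-type nitrogen, the pent-1-en-1-yl chain and its double bond outside aromatic rings are therefore not required for a number in this range, since the shorter ethyl, which has no such double bond, serves equally well on this shared core. This finding rests on a single pair and says nothing about how the same change would read on the core of compound 1, which differs from both compounds at more than one place.

On these data alone, it remains open whether methyl, a longer saturated chain such as butyl, or a phenyl ring on the same carbonyl carbon would also keep the number in this range, so the limits of what this position tolerates are not yet defined. No independent measurement is available to explain why the two chains give such similar numbers.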